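The source may hold more compounds than are shown below. What is called first, only, known or untested is meant among the compounds shown, and "the series" means these compounds.

Measured in a functional assay on HOP-62 cells (Homo sapiens) for inhibition, read by sulforhodamine B assay; on this read-out lower numbers stand for stronger inhibition of growth and higher numbers for weaker inhibition of growth:
- compound 1 `FC(F)(F)Oc1ccc(-c2ccc(-c3ccc(-c4nc5ccccc5[nH]4)cc3)cc2)cc1`: 100000 nM
- compound 2 `Oc1ccc(-c2ccc(-c3ccc(-c4nc5ccccc5[nH]4)cc3)cc2)cc1`: 47200 nM

Compound 2, at 47200 nM, holds the lower of the two numbers. Compound 3 `COc1ccc(-c2ccc(-c3ccc(-c4nc5ccccc5[nH]4)cc3)cc2)cc1` differs from it as follows: methyl in place of hydrogen on an oxygen on an aromatic ring, with methyl in place of hydrogen on an oxygen on an aromatic ring, hydroxy to methoxy. Within the data shown here, one measured step bears on this, at the same oxygen: a 2.1-fold lower number from compound 1 to compound 2 (0.33 log units; beyond the scatter), a modest one. Compound 3 again carries a group there, as compound 1 does, so a small upward step in this assay is expected, probably not beyond the scatter. For compound 3 the estimated value is 70000 nM, within an expected range of 30000 nM to 100000 nM. This estimate means an expected 1.5-fold higher number from compound 2 to compound 3 (0.17 log units; within the scatter).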

Compound 3, concentration for 50% growth inhibition: 100000 nM
Compound 3: the middle estimate sits 1.4-fold (0.15 log units) below what was measured, and the stated range covers the measured number.
By their numbers in this assay, from the lowest: compound 2; then compounds 1 and 3 (each within the scatter of the next).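

In this assay, methyl on the oxygen behaves like trifluoromethyl: a 2.1-fold higher number from compound 2 to compound 3 (0.33 log units; beyond the scatter), and no change at the digits printed from compound 1 to compound 3 (within the scatter). Among these three compounds, only the free hydroxy of compound 2 stands apart, while the two capped oxygens cannot be told apart. Nothing measured here offers a reason for this.

Going by these compounds, whether the lower number belongs to the hydroxy itself, or would also appear with an amine or a carboxylic acid in its place, stays open. So does whether a longer chain on the oxygen would match methyl.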